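Changing the Group on the Uracil Ring of a Diphosphate

The source may report more compounds than this note shows. Statements on the series, on what has been measured and on what is new or still open speak of the compounds shown alone.

Compound 1 `COc1nc(=O)ccn1[C@@H]1O[C@H](COP(=O)(O)OP(=O)(O)O)[C@@H](O)[C@H]1O` and compound 2 `O=c1ccn([C@@H]2O[C@H](COP(=O)(O)OP(=O)(O)O)[C@@H](O)[C@H]2O)c(SCc2ccccc2)n1` share one core and differ in a single group on an aromatic carbon. In an in vitro functional assay on 1321-N1 cells for agonist activity at P2Y purinoceptor 4 (Homo sapiens), read by scintillation proximity assay and inositol phosphate accumulation (a lower number here means that less compound is needed, a higher number that more compound is needed for the effect), compound 1 gives 4490 nM, while in this assay compound 2 gives 5980 nM. That exchange, a 1.3-fold higher number from compound 1 to compound 2 (0.12 log units; within the scatter), left the number essentially unmoved. Compound 2 thus carries the higher of the two numbers, but its gap to compound 1 sits inside the scatter, so neither compound can be ranked above the other.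

Compound 3 `CNc1nc(=O)ccn1[C@@H]1O[C@H](COP(=O)(O)OP(=O)(O)O)[C@@H](O)[C@H]1O` has not been measured. It differs from compound 2 as follows: methylamino in place of benzylsulfanyl on an aromatic carbon. Within the data shown here, the one step known at this position was within the scatter, which gives little reason to expect a large shift in this assay for compound 3, though the incoming group is small and carries a hydrogen-bond donor, which the data cannot speak to. Compound 3 is therefore estimated at 5000 nM, ranging from 1500 nM to 16000 nM, an expected step of a 1.2-fold lower number from compound 2 to compound 3 (0.08 log units; within the scatter).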

Compound 3, half-maximal effective concentration: >= 100000 nM
Compound 3 gave a limit, no number; the forecaster's own chance of this, stated with the estimate: 10%; middle value at least 20-fold (1.30 log units) from the limit.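

Compound 3 gives a limit, not a number: the limit of >= 100000 nM in this assay, at which 1 of the 3 values shown sits. Even so, the steps show that this position does not accept every group: methylamino in place of benzylsulfanyl gives an at least 16-fold higher number from compound 2 to compound 3 (1.22 log units; beyond the scatter), and methylamino in place of methoxy gives an at least 22-fold higher number from compound 1 to compound 3 (1.34 log units; beyond the scatter). The earlier exchange of methoxy for benzylsulfanyl stayed within the scatter, so the two earlier compounds alone gave no sign that the group at this position could matter so much in this assay.

The compounds shown leave open whether the jump goes with the nitrogen link, its hydrogen-bond donor or the small size of methylamino. Benzylamino would keep the benzyl group on a nitrogen link, and dimethylamino would keep that link without the amine hydrogen, so each would separate these possibilities.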